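The compounds below may be only part of what the source reports. "The series", "measured", "known", "first", "only" and "open" are said of these compounds alone.

Compound 1 `CN(C)C(=O)c1cc2cnc(Nc3ccc(NC(=O)C4(C(=O)Nc5ccccc5F)CC4)cc3)nc2n1C1CCCC1` is the starting point. Going by the values given here, in a functional assay on A549 cells (Homo sapiens) for inhibition, read by CCK-8 assay, with a stated time of 72 h, tested at 1 uM (a lower number here means less inhibition of growth, a higher number more inhibition of growth at the concentration tested), compound 1 gives 79.1%, the highest of the three numbers known so far. Compound 2 `Nc1ccc(NC(=O)C2(C(=O)Nc3ccc(F)cc3)CC2)cc1F` gives 16.3% in this assay, and compound 3 `CN(C)C(=O)c1cc2cnc(Nc3ccc(NC(=O)C4(C(=O)Nc5ccc(Cl)c(C(F)(F)F)c5)CC4)cc3)nc2n1C1CCCC1` gives 1.1%. Among the compounds with values here, only one measured step bears on the change at hand: a number 78 percentage points lower from compound 1 to compound 3 (beyond the scatter), a large fall. Within the data shown here, compound 4 `CN(C)C(=O)c1cc2cnc(Nc3ccc(NC(=O)C4(C(=O)Nc5cccc(Br)c5)CC4)cc3)nc2n1C1CCCC1` differs from compound 1 in the same place, (3-bromophenyl in place of 2-fluorophenyl on an amide-type nitrogen), yet the group that enters here is not the one that entered in compound 3, so that step is only a loose guide. A fall of some size is therefore expected, with wide uncertainty. Compound 4 is expected to give 40% in this assay, between 5% and 85%, a step of a number 39.1 percentage points lower from compound 1 to compound 4 (beyond the scatter).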

Compound 4, percent growth inhibition at one concentration: 20.2%
Compound 4: middle estimate off by 19.8 percentage points, on the high side, within the range that was stated.
By their numbers in this assay, from the lowest: compound 3; then compounds 2 and 4 (each within the scatter of the next); then compound 1.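

Replacing 2-fluorophenyl with 3-bromophenyl on this amide-type nitrogen gives a number 58.9 percentage points lower from compound 1 to compound 4 (beyond the scatter) in this assay, so a large fall at this position is not confined to the group carried by compound 3. The two lower groups are also distinguishable from each other, with a number 19.1 percentage points higher from compound 3 to compound 4 (beyond the scatter), so this position separates even groups that both fall well short of compound 1. Nothing measured here gives a reason for these steps.

From the compounds shown here alone, it remains open whether the standing of compound 1 depends on its fluorine. An unsubstituted phenyl, a 2-chlorophenyl or an aminophenyl on the same nitrogen could help settle this.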